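The compounds below may be only part of what the source reports. "The series", "measured", "known", "first", "only" and "open" are said of these compounds alone.

Two compounds on the shared core, compound 1 `CC(C)(CO)CNC(=O)c1cc2cc(C#N)ccc2n1Cc1cccc(OC(F)(F)F)c1` and compound 2 `CC(C)(CO)CNC(=O)c1cc2cc(C#N)ccc2n1Cc1cc(Cl)cc(Cl)c1`, have been measured in an in vitro ADME assay on microsomes from Gut (Homo sapiens) for metabolic stability, using NADPH; a lower number here means slower removal, a higher number faster removal of the compound. In this assay compound 1 gives < 6 mL.min-1.g-1, which is a limit and not a number. As far as these compounds go, compound 2 gives < 6 mL.min-1.g-1, which is likewise only a limit, so its exact position is unknown. Among the compounds with values here, the whole picture so far is the limit of < 6 mL.min-1.g-1 in this assay, at which 2 of the 2 values shown sit, and no step between measured compounds is available. Compound 3 `COc1ccc(Br)cc1Cn1c(C(=O)NCC(C)(C)CO)cc2cc(C#N)ccc21` differs from compound 2 in one place, with 5-bromo-2-methoxyphenyl in place of 3,5-dichlorophenyl on a saturated chain carbon bound to an aromatic nitrogen. Cut one bond further out, the same difference reads 3,5-dichlorobenzyl to 5-bromo-2-methoxybenzyl. In this assay the expected step that the limit leaves unreadable from compound 2 to compound 3 is none beyond the usual scatter, with any small movement more likely towards faster removal, since a limit leaves little room below it. This expectation rests on compound 2 and its limit of < 6 mL.min-1.g-1. For compound 3 the estimated value is 5 mL.min-1.g-1, with an expected range from 3 mL.min-1.g-1 to 10 mL.min-1.g-1, and the result may well be only a limit.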

Compound 3, intrinsic clearance in microsomes: < 6 mL.min-1.g-1
Compound 3: a limit, no number; the forecaster's own chance of this, stated with the estimate: 70%; the middle value lies beyond the limit too.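

In this assay compound 3 gives < 6 mL.min-1.g-1, which is a limit and not a number. Within the data shown here, compound 2 also has only a limit, so no step between compound 2 and compound 3 can be read. The compounds shown leave open whether 5-bromo-2-methoxyphenyl in place of 3,5-dichlorophenyl changes the clearance at all, as every value is a limit: the limit of < 6 mL.min-1.g-1 in this assay, at which 3 of the 3 values shown sit.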